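The compounds below may be only part of what the source reports. "The series", "measured", "known", "first", "only" and "open" are said of these compounds alone.

Two compounds share a core and were tested in an assay on MDA-MB-231 cells for binding affinity to C-X-C chemokine receptor type 4 (Homo sapiens), read by immunofluorescence and microscopy, with stated times of 10 min and 30 min; a higher number here means that more compound is needed for the effect, a lower number that less compound is needed. Compound 1 is `Cc1ccc(S(=O)(=O)NCc2ccc(CNC(=O)c3ccccc3)cc2)cc1`, and compound 2 is `COc1ccc(C(=O)NCc2ccc(CNS(=O)(=O)c3ccccc3)cc2)cc1`. In this assay compound 2 gives 1000 nM. For compound 1 this assay reports only a limit rather than a number, > 1000 nM. Compound 1 therefore sits at the limit of > 1000 nM in this assay, at which 1 of the 2 values shown sits, so its exact standing on the numbers is not known. Going by the values given here, no step between two measured compounds can be read from these data. Compound 3 is `Cc1ccc(S(=O)(=O)NCc2ccc(CNC(=O)c3ccccc3Cl)cc2)cc1` and has not yet been measured in this assay. It differs from compound 1 by chloro in place of hydrogen on an aromatic carbon. Among the compounds with values here, with no measured step to lean on, the expected step is a step that the limit leaves unreadable from compound 1 to compound 3, which is not expected to reach beyond the usual scatter. Compound 3 is accordingly estimated at 1200 nM, with a range from 400 nM to 5000 nM.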

Compound 3, effective concentration (reported as EC, without a stated level of effect): 10 nM
Compound 3: middle estimate off by 120-fold (2.08 log units), on the high side; measured number outside the range, below it.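

Chloro in place of hydrogen on an aromatic carbon, ortho to a large group, gives an at least 100-fold lower number from compound 1 to compound 3 (2.00 log units; beyond the scatter) in this assay. Going by these compounds alone, the earlier compounds offered no readable step, so this is the first evidence that the shared core responds to a change at this place, and that a single added chlorine atom, turning phenyl into 2-chlorophenyl, can move the number well beyond the scatter. The step is a minimum rather than an exact size because compound 1 rests on a limit: the limit of > 1000 nM in this assay, at which 1 of the 3 values shown sits.

Still open, as far as these compounds go, is whether chlorine is special at this carbon, or whether fluoro, methyl or an amine there would give a similar step. Also open, from the compounds shown here alone, is whether chloro on another carbon of the same ring would have a comparable effect.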